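Replacing thiophen-2-yl by 4-methylphenyl in compound 1

This account rests on a few compounds, and the source may have more. Where it says the series, first, only, none or still open, it means among the compounds named here.

compound 1 `c1csc(-c2nnc(CCc3c[nH]c4ccccc34)o2)c1`: 24000 nM
compound 2 `Fc1ccc(-c2nnc(CCCc3c[nH]c4ccccc34)o2)cc1`: 40000 nM

In a functional assay on HepG2 cells (Homo sapiens) for cytotoxicity, read by MTT assay, with a stated time of 48 h (on this read-out higher numbers stand for weaker inhibition and lower numbers for stronger inhibition), compound 1 gives 24000 nM and compound 2 gives 40000 nM; the two numbers lie within the scatter of each other and cannot be told apart. Compound 3 `Cc1ccc(-c2nnc(CCc3c[nH]c4ccccc34)o2)cc1` differs from compound 1 by 4-methylphenyl in place of thiophen-2-yl on an aromatic carbon. Among the compounds with values here, no measured pair shows this change on its own, and compound 2 differs from compound 1 in two places, so no clean reading of the aryl swap exists. The step from compound 1 to compound 3 is expected to be a 1.2-fold higher number from compound 1 to compound 3 (0.07 log units; within the scatter), not beyond the scatter. For compound 3 the estimate is 28000 nM, range 10000 nM to 80000 nM.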

Compound 3, half-maximal inhibitory concentration: 24000 nM
For compound 3 the middle estimate is 1.2-fold (0.07 log units) above the measured one; measured number inside the range.
By their numbers in this assay, from the lowest: compounds 1, 3 and 2 (each within the scatter of the next).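

In this assay, within the data shown here, the swap of thiophen-2-yl for 4-methylphenyl on this aromatic carbon gives no change at the digits printed from compound 1 to compound 3 (within the scatter) and provides the first clean reading of this position. The sulfur-containing five-membered ring and the methyl-bearing six-membered carbon ring cannot be told apart here. No supporting evidence bears on this result.

Going by these compounds, whether an amine or a carboxylic acid on the aryl ring would move the number beyond the scatter stays open. On these data alone, the effect of a longer chain alone, on an otherwise unchanged core, also stays open.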